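Adding a chloro group to compound 2

The source may report more compounds than this note shows. Statements on the series, on what has been measured and on what is new or still open speak of the compounds shown alone.

compound 1 `COc1cc(/C=C/C(=O)/C=C/c2nc3cc(Cl)ccc3n2C)ccc1O` gives 8900 nM
compound 2 `COc1ccc(/C=C/C(=O)/C=C/c2nc3ccccc3n2C)cc1O` gives 6900 nM
compound 3 `COc1ccc(/C=C/C(=O)/C=C/c2nc3c(C)cccc3n2C)cc1O` gives 25400 nM

All three numbers come from a functional assay on NCI-H460 cells (Homo sapiens) for cytotoxicity, read by MTT assay, with a stated time of 48 h; on this read-out lower numbers stand for stronger inhibition and higher numbers for weaker inhibition. Compound 2 and compound 1 lie within the usual scatter of each other, so neither can be ranked above the other, while compound 3 has the clearly higher number.

The next compound, compound 4 `COc1ccc(/C=C/C(=O)/C=C/c2nc3cc(Cl)ccc3n2C)cc1O`, alters compound 2 in a single place: chloro in place of hydrogen on an aromatic carbon. In words, this is chloro in place of hydrogen on an aromatic carbon. Its number in this assay is not yet known.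

For the measured compounds named here, only one measured step resembles this change, and only loosely. With methyl in place of hydrogen on an aromatic carbon, the data show a 3.7-fold higher number from compound 2 to compound 3 (0.57 log units; beyond the scatter), so one swap of this kind can move the number upward by a modest amount. Going by the values given here, compound 1 also carries a chloro group and gives 8900 nM, but no single-place step links it to compound 2, so it is only a rough guide.

Taken together, these point to little change, with a slight lean toward a higher number. The expected change is a 1.2-fold higher number from compound 2 to compound 4 (0.06 log units; within the scatter), which stays within the scatter. For compound 4 the estimated value is 8000 nM, with an expected range from 3500 nM to 18000 nM.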

Compound 4, half-maximal inhibitory concentration: 7300 nM
The estimate for compound 4 lay 1.1-fold (0.04 log units) above the measured number, and the stated range covers the measured number.
By their numbers in this assay, from the lowest: compounds 2, 4 and 1 (each within the scatter of the next); then compound 3.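

In this assay, putting chloro in place of hydrogen on this aromatic carbon gives a 1.1-fold higher number from compound 2 to compound 4 (0.02 log units; within the scatter), so this carbon of the fused ring system accepts a chlorine atom with no change that can be told from ordinary assay noise. For the compounds shown here, that sets it apart from the only earlier single-place step, a methyl group on another carbon of the same ring, which gave a 3.7-fold higher number from compound 2 to compound 3 (0.57 log units; beyond the scatter) and lay beyond the scatter, so swapping a hydrogen on this ring does not always leave the number where it was. Since those two steps differ in both the group and the carbon, and no measurement here explains the contrast, the data cannot say which of the two matters.

On these data alone, it remains open whether this carbon would accept something larger or of a different kind, such as an amine, a carboxylic acid or a longer alkyl chain, as readily as it accepts chloro. Also unsettled is how chloro would behave on the carbon that carries the methyl group in compound 3, which would show whether that carbon or the methyl group lies behind the higher number.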